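This account rests on a few compounds, and the source may have more. Where it says the series, first, only, none or still open, it means among the compounds named here.

In a functional assay on A549 cells (Homo sapiens) for antiproliferative activity, read by MTT assay, with a stated time of 72 h (a higher number here means a weaker inhibitor, a lower number a stronger inhibitor), compound 2 `O=C(C1=C(Nc2ccc(OC(F)(F)F)cc2)C(=O)N(CCCn2ccnc2)C1c1ccc(Br)cc1)c1ccccc1` gives 20800 nM, and compound 1 `Cc1ccc(NC2=C(C(=O)c3ccccc3)C(c3ccc(Br)cc3)N(CCCn3ccnc3)C2=O)cc1` gives 29400 nM; the two numbers lie within the usual scatter of each other, so neither stands apart. Among the compounds with values here, the only measured step, a 1.4-fold lower number from compound 1 to compound 2 (0.15 log units; within the scatter), is itself within the scatter. Compound 3 `O=C(C1=C(Nc2ccccc2Br)C(=O)N(CCCn2ccnc2)C1c1ccc(Br)cc1)c1ccccc1` differs from compound 2 by 2-bromophenyl in place of 4-(trifluoromethoxy)phenyl on an amine nitrogen. Within the data shown here, no measured step covers a change of this kind, and the one step known shows no movement beyond the scatter, so the expectation is a step of little size in this assay, in no firm direction. Compound 3 is therefore expected to give about 22000 nM, within a range from 9000 nM to 55000 nM, which is estimated as a 1.1-fold higher number from compound 2 to compound 3 (0.02 log units; within the scatter).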

Compound 3, half-maximal inhibitory concentration: 20100 nM
Estimate against measurement, compound 3: 1.1-fold (0.04 log units) above, within the range that was stated.
By their numbers in this assay, from the lowest: compounds 3, 2 and 1 (each within the scatter of the next).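

Putting 2-bromophenyl on the amine nitrogen gives a 1.0-fold lower number from compound 2 to compound 3 (0.01 log units; within the scatter) and a 1.5-fold lower number from compound 1 to compound 3 (0.17 log units; within the scatter) in this assay. So a third group, now carrying bromine rather than trifluoromethoxy or methyl, also leaves the number within the scatter of the others, and 4-methylphenyl, 4-(trifluoromethoxy)phenyl and 2-bromophenyl cannot be told apart here. Nothing available explains why these numbers stay together.

Still open, on these data alone, is whether a phenyl ring carrying a carboxylic acid or an amine, or a plain alkyl chain in place of the ring, would move the number beyond the scatter.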